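The source may hold more compounds than are shown below. What is called first, only, known or untested is meant among the compounds shown, and "the series" means these compounds.

Measured so far in a functional assay on MCF7 cells (Homo sapiens) for inhibition, read by sulforhodamine B assay, with a stated time of 48 h, tested at 50 uM; a higher number here means more inhibition of growth at the concentration tested, a lower number less inhibition of growth:
compound 1, `COc1cc2c(cc1CC=C(C)C)C(=O)C[C@@H](c1ccc(Oc3ccccc3)cc1)O2`: 69%
compound 2, `COc1ccc([C@@H]2CC(=O)c3cc(CC=C(C)C)c(OC)cc3O2)cc1`: 65%
compound 3, `C#CCOc1ccc([C@@H]2CC(=O)c3cc(CC=C(C)C)c(OC)cc3O2)cc1`: 68%

Compound 3 stands second highest of the three numbers, with compound 1 nearest and compound 2 furthest; both gaps lie within the scatter, so the three values are not separable. Compound 4 is `CCCCOc1ccc([C@@H]2CC(=O)c3cc(CC=C(C)C)c(OC)cc3O2)cc1`; its change from compound 3 is propyl in place of ethynyl on a saturated chain carbon bound to an oxygen on an aromatic ring. The step that touches the same carbon is a number 3 percentage points higher from compound 2 to compound 3 (within the scatter), within the scatter, and the two other steps, a number 4 percentage points lower from compound 1 to compound 2 (within the scatter) and a number 1 percentage points lower from compound 1 to compound 3 (within the scatter), are likewise within it. Nothing in this set moves the number when the group on this oxygen is varied, so no step beyond the scatter is expected for propyl in place of ethynyl: the expected step is a number 2 percentage points lower from compound 3 to compound 4 (within the scatter). Compound 4 is therefore estimated at 66%, between 55% and 77%.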

Compound 4, percent growth inhibition at one concentration: 57%
Compound 4: middle estimate off by 9 percentage points, on the high side; low and high end bracket the measured number.
By their numbers in this assay, from the lowest: compounds 4, 2, 3 and 1 (each within the scatter of the next, the first and the last beyond it).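

In this assay, for the compounds shown here, varying the group on this oxygen now separates compounds for the first time: propyl in place of ethynyl gives a number 11 percentage points lower from compound 3 to compound 4 (beyond the scatter), and butyl in place of phenyl gives a number 12 percentage points lower from compound 1 to compound 4 (beyond the scatter). The separation is incomplete, since propyl in place of hydrogen gives only a number 8 percentage points lower from compound 2 to compound 4 (within the scatter), so compound 2 cannot be told apart from compound 4. No evidence at hand bears on this result.

Open, on these data alone, is whether a longer chain such as hexyl would read lower still. Also open, as far as these compounds go, is how an amine or a carboxylic acid at the end of this chain would read.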